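The source may hold more compounds than are shown below. What is called first, only, known or untested is meant among the compounds shown, and "the series" means these compounds.

Compound 1 `COc1ccc(-c2nc3sc(Cc4ccccc4)nn3c2SC#N)cc1`: 5800 nM
Compound 2 `Clc1ccc(-c2cn3nc(Cc4ccccc4)sc3n2)cc1`: 3700 nM
Compound 3 `O=Cc1c(-c2ccc(Br)cc2)nc2sc(Cc3ccccc3)nn12`: 3200 nM

The three compounds were tested in a functional assay on cells (Melanoma cell, Homo sapiens) for inhibition; a lower number here means a stronger inhibitor of growth, a higher number a weaker inhibitor of growth. Compound 1 gives 5800 nM, compound 2 gives 3700 nM and compound 3 gives 3200 nM. Compound 3 has the lowest of the three numbers, but its nearest neighbour, compound 2, and its furthest, compound 1, both lie within the usual scatter of it, so the three are best read as equally active within the precision of this assay.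

Compound 4 `O=Cc1c(-c2ccc([N+](=O)[O-])cc2)nc2sc(Cc3ccccc3)nn12` is not yet measured. It differs from compound 3 in one place: nitro in place of bromo on an aromatic carbon. The rest of the shared core, including the benzyl group and the carbonyl on the core, is unchanged.

Among the measured compounds shown here, no step between measured compounds teaches what a nitro in place of a bromo does in this assay, so there is no observed precedent to lean on. The expectation is a step from compound 3 to compound 4 of no change at the digits printed from compound 3 to compound 4 (within the scatter), that is, no change beyond the scatter. On that basis compound 4 is estimated at 3200 nM, with a range from 1200 nM to 8500 nM.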

Compound 4, concentration for 50% growth inhibition: 3700 nM
Beside the measured number, compound 4's estimate is 1.2-fold (0.06 log units) below it; measured number inside the range.
By their numbers in this assay, from the lowest: compounds 3, 2, 4 and 1 (each within the scatter of the next).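

Among the compounds shown here, putting nitro in place of bromo on the aromatic carbon, para to a large group, gives in this assay a 1.2-fold higher number from compound 3 to compound 4 (0.06 log units; within the scatter) and so provides the first comparison here in which only one place differs. The earlier compounds shown here differ from one another in more than one place, so they could not isolate the effect of this position. This pair shows that a bromine atom can give way to a group with more heavy atoms, made of nitrogen and oxygen and carrying hydrogen-bond acceptors, without the assay separating the two compounds. Nothing measured here bears on why these two groups read alike.

On these data alone, one exchange says little about the position as a whole, so it remains open whether an amine or a carboxylic acid at the same aromatic carbon would also stay within the scatter of compound 3. The benzyl group and the carbonyl are also the same in compound 3 and compound 4, so this pair does not show how a longer chain in place of the benzyl group, or a carboxylic acid in place of the carbonyl, would read.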